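Adding bromo to the core of compound 3

A few compounds are considered here, and "the series" means these few. Any claim that something is new, unique, unknown or untested is made for them only; others in the source may bear on it.

Measured in a functional assay on SK-OV-3 cells (Homo sapiens); a lower number here means a stronger inhibitor of growth, a higher number a weaker inhibitor of growth:
Compound 1 `N#Cc1ccc(/C=C/S(=O)(=O)Cc2ccc(Nc3ncnc4ccccc34)cc2)cc1`: > 100000 nM, a limit of the assay
Compound 2 `O=S(=O)(/C=C/c1ccc(Cl)c(Cl)c1)Cc1ccc(Nc2ncnc3ccccc23)cc1`: 22000 nM
Compound 3 `O=S(=O)(/C=C/c1ccc(F)cc1F)Cc1ccc(Nc2ncnc3ccccc23)cc1`: 69000 nM

Of the two actual numbers, compound 3 holds the higher at 69000 nM. The entry for compound 1 is a limit.

Compound 4 `O=S(=O)(/C=C/c1ccc(F)cc1F)Cc1ccc(Nc2ncnc3ccc(Br)cc23)cc1` differs from compound 3 by bromo in place of hydrogen on an aromatic carbon. For the measured compounds named here, no measured step touches that place, so the evidence is indirect. All three steps exchange the aryl group on the chain instead. One of them is an at least 4.5-fold lower number from compound 1 to compound 2 (0.65 log units; beyond the scatter), and it gives only a floor because of the limit of > 100000 nM in this assay, at which 1 of the 3 values shown sits. Another is an at least 1.4-fold lower number from compound 1 to compound 3 (0.16 log units; that floor lies within the scatter). Going by the values given here, the only step with two actual numbers is a 3.1-fold higher number from compound 2 to compound 3 (0.50 log units; beyond the scatter).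

Taking that last step as a guide to size, a modest shift in this assay is expected, probably towards a lower number, though the direction is uncertain. The expected change is a 2.3-fold lower number from compound 3 to compound 4 (0.36 log units; beyond the scatter). Compound 4 is estimated at 30000 nM, with an expected range of 8000 nM to 100000 nM.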

Compound 4, concentration for 50% growth inhibition: 2000 nM
Compound 4: the middle estimate sits 15-fold (1.18 log units) above what was measured, outside the stated range (below it).
By their numbers in this assay, from the lowest: compound 4; then compound 2; then compound 3. At a limit, above all of these: compound 1.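

Moving from the aryl group on the chain to the shared core, this assay shows a far stronger response to this one-atom change: a 35-fold lower number from compound 3 to compound 4 (1.54 log units; beyond the scatter). For the compounds shown here, that step exceeds the only aryl exchange with two actual numbers, which is a 3.1-fold higher number from compound 2 to compound 3 (0.50 log units; beyond the scatter). The aromatic carbon carrying the bromo, in a six-membered aromatic ring of carbon only that is part of a fused system of two rings, therefore emerges as a sensitive place in this short series, although nothing shown here accounts for the gain.

As far as these compounds go, whether the gain belongs to bromo itself remains open, since no other group, such as chloro, methyl or an amine, appears at this place. From the compounds shown here alone, it also remains open whether bromo would act similarly alongside the 3,4-dichlorophenyl group of compound 2.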